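Moving the Chlorine to Another Ring Position

The source may hold more compounds than are shown below. What is called first, only, known or untested is meant among the compounds shown, and "the series" means these compounds.

Measured compounds:
compound 1 `O=C(N/N=C/c1cccc(F)c1)c1cccnc1Nc1cccc(C(F)(F)F)c1`: 58.3%
compound 2 `O=C(N/N=C/c1cccc(Cl)c1)c1cccnc1Nc1cccc(C(F)(F)F)c1`: 77.8%

In a functional assay on the whole organism (strain Wistar) for inhibition, with Rattus norvegicus as the target, read by paw edema, with a stated time of 30 min, at a dose of 10 mg/kg by the intraperitoneal route (on this read-out lower numbers stand for less inhibition and higher numbers for more inhibition at the one dose given (going by the name of the read-out)), compound 2 holds the higher of the two numbers, with compound 1 the nearest, a step of a number 19.5 percentage points higher from compound 1 to compound 2 (beyond the scatter) behind it. Compound 3 `O=C(N/N=C/c1ccc(Cl)cc1)c1cccnc1Nc1cccc(C(F)(F)F)c1` differs from compound 2 by 4-chlorophenyl in place of 3-chlorophenyl on a carbon with a double bond to nitrogen. Among the measured compounds shown here, the one measured step, a number 19.5 percentage points higher from compound 1 to compound 2 (beyond the scatter), exchanges one halogen for another and keeps its position, so no measured step bears on a move of the same chlorine around its ring. No step beyond the scatter is therefore expected. Compound 3 is estimated at 72%, between 52% and 90%. The step this estimate means is expected to be a number 5.8 percentage points lower from compound 2 to compound 3 (within the scatter).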

Compound 3, a percentage reported as inhibition, in the whole organism at one dose (the size of the read-out at that dose, not a potency): 52.4%
Beside the measured number, compound 3's estimate is 19.6 percentage points above it; measured number inside the range.
By their numbers in this assay, from the lowest: compounds 3 and 1 (each within the scatter of the next); then compound 2.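

The change to 4-chlorophenyl in place of 3-chlorophenyl brings a number 25.4 percentage points lower from compound 2 to compound 3 (beyond the scatter) in this assay and shows that where the chlorine sits on this ring counts, not only which halogen is present. With 4-chlorophenyl in place of 3-fluorophenyl, the result is a number 5.9 percentage points lower from compound 1 to compound 3 (within the scatter) and no real separation between the two compounds. Nothing available explains the effect of moving the chlorine. The compounds shown leave open whether a methoxy group or an amine in place of the chlorine of compound 2 would keep its number in this model.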